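A Trifluoromethyl Swap Repeated on a Second Core

The source may report more compounds than this note shows. Statements on the series, on what has been measured and on what is new or still open speak of the compounds shown alone.

Three compounds have so far been measured in a functional assay on PC-3 cells (Homo sapiens) for cytotoxicity, read by MTT assay, with a stated time of 72 h; a lower number here means a stronger inhibitor, a higher number a weaker inhibitor:

compound 1, `O=C(Nc1ccc(Oc2ccnc3[nH]ccc23)cc1)c1nn(-c2ccc(Cl)c(F)c2)ccc1=O`, which gives 7780 nM;
compound 2, `O=C(Nc1ccc(Oc2ccnc3[nH]ccc23)cc1)c1nn(-c2ccc(Cl)c(C(F)(F)F)c2)ccc1=O`, which gives 4630 nM;
compound 3, `Cn1ccc2c(Oc3ccc(NC(=O)c4nn(-c5ccc(Cl)c(F)c5)ccc4=O)cc3F)ccnc21`, which gives 17900 nM.

Compound 1 and compound 2 share one core and differ at a single place: trifluoromethyl in place of fluoro on an aromatic carbon. This change produced a 1.7-fold lower number from compound 1 to compound 2 (0.23 log units; within the scatter), so the two numbers cannot be told apart with confidence. Compound 3 carries a different core; how its core differs from that of compound 1 is not broken down here. Its number is the highest of the three, and it lies beyond the usual scatter from both compound 1 and compound 2.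

Compound 4, `Cn1ccc2c(Oc3ccc(NC(=O)c4nn(-c5ccc(Cl)c(C(F)(F)F)c5)ccc4=O)cc3F)ccnc21`, is built on the core of compound 3 and differs from it at one place only: trifluoromethyl in place of fluoro on an aromatic carbon. Among the compounds with values here, the surroundings of the change are described in the same words for both pairs, so this is the same change as the one from compound 1 to compound 2. On that basis the step is expected to be a 1.7-fold lower number from compound 3 to compound 4 (0.23 log units; within the scatter), sitting beside a 1.7-fold lower number from compound 1 to compound 2 (0.23 log units; within the scatter) and resting on nothing more than that single earlier pair. Compound 4 is therefore estimated at 10500 nM in this assay, with a likely range from 5000 nM to 22000 nM.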

Compound 4, half-maximal inhibitory concentration: 20900 nM
Estimate against measurement, compound 4: 2.0-fold (0.30 log units) below; the measured number falls inside the stated range.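

In this assay, trifluoromethyl in place of fluoro, read one bond further out as 4-chloro-3-fluorophenyl to 4-chloro-3-(trifluoromethyl)phenyl, gives a 1.2-fold higher number from compound 3 to compound 4 (0.07 log units; within the scatter), so the two numbers on the core of compound 3 cannot be told apart with confidence, just as on the core of compound 1. The two steps are printed with opposite signs, but that difference carries no weight, and on both cores the change stays within the usual scatter of this assay: the same change on two cores in this assay, a 1.7-fold lower number (0.23 log units; within the scatter) from compound 1 to compound 2 and a 1.2-fold higher number (0.07 log units; within the scatter) from compound 3 to compound 4, 2.0-fold (0.29 log units) apart, within the scatter of two such steps. This shows that in these two pairs the change had no effect that can be distinguished from scatter on either core, but it does not show that the change is without effect in this series, nor that a small real step would have the same size or direction on both cores, and two pairs are too few to settle either point.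

The compounds shown leave open whether another group at this place, such as a nitrile, a methoxy group or an amine, would give a step beyond the scatter on either core. Also open, going by these compounds, is what the chloro group common to all four compounds contributes, for instance when set against a hydrogen or a methyl group there.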